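The source may report more compounds than this note shows. Statements on the series, on what has been measured and on what is new or still open speak of the compounds shown alone.

Measured compounds:
compound 1, `Cc1nc(N)sc1CCCN/C(N)=N/C(=O)N[C@H](C)c1ccccc1`: 0.34
compound 2, `CCCCCCNC(=O)/N=C(\N)Nc1cccc(-c2csc(N)n2)c1`: "not determined" (no result reported)

Going by the values given here, in a functional assay on HEK293T cells for agonist activity at histamine H2 receptor (Homo sapiens), read by beta-arrestin recruitment (on this read-out lower numbers stand for smaller maximal responses and higher numbers for larger maximal responses), compound 1 gives 0.34, the only number this series holds. For compound 2 the read-out in this assay is "not determined" (no result reported), so it offers no comparison. Compound 3, `Cc1nc(N)sc1CCCN/C(N)=N/C(=O)Nc1ccccc1`, differs from compound 1 in one place: phenyl in place of 1-phenylethyl on an amide-type nitrogen. Among the compounds with values here, no measured pair shows what such a change does here, so any expectation rests on compound 1 alone. The step from compound 1 to compound 3 is expected to be small, a number 0.060 higher from compound 1 to compound 3 (within the scatter), not beyond the usual scatter in either direction. Compound 3 is therefore estimated at 0.4, within a range from 0.15 to 0.65.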

Compound 3, intrinsic activity: the largest response reached, as a fraction of the reference agonist's: 0.25
Beside the measured number, compound 3's estimate is 0.15 above it; measured number inside the range.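

In this assay, phenyl in place of 1-phenylethyl on the amide-type nitrogen gives a number 0.090 lower from compound 1 to compound 3 (within the scatter). This first measured pair shows that, on this read-out, the position accepts the smaller group without a step beyond the scatter, even though the defined stereocentre leaves with 1-phenylethyl. Nothing available bears on the reason for this result. Still open, as far as these compounds go, is whether a longer chain, such as hexyl, or a group carrying an amine would give a step beyond the scatter at this nitrogen. The compounds shown also leave open how the opposite stereocentre in 1-phenylethyl would read.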